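Benzamide substituent variation on a thiazole carboxylic acid series

A few compounds are considered here, and "the series" means these few. Any claim that something is new, unique, unknown or untested is made for them only; others in the source may bear on it.

Measured compounds:
compound 1 `CCOC(=O)c1sc(-c2cccc(NC(=O)c3ccc(Cl)cc3)c2)nc1Nc1ccc(N2CCN(C)CC2)cc1`: "not determined" (no result reported) in a functional assay on Ramos cells (Homo sapiens) for antiproliferative activity, read by CCK-8 assay, with a stated time of 72 h; a lower number here means a stronger inhibitor, a higher number a weaker inhibitor
compound 2 `CN1CCN(c2ccc(Nc3nc(-c4cccc(NC(=O)c5ccccc5F)c4)sc3C(=O)O)cc2)CC1`: 6300 nM

Among the measured compounds shown here, compound 2 gives the only number in this assay; compound 1 was not determined, so compound 2 stands alone and no step between measured compounds can be read. Compound 3 `CN1CCN(c2ccc(Nc3nc(-c4cccc(NC(=O)c5ccc(Cl)cc5)c4)sc3C(=O)O)cc2)CC1` differs from compound 2 by 4-chlorophenyl in place of 2-fluorophenyl on a carbonyl carbon. For the measured compounds named here, with no comparable step to draw on, the expected step from compound 2 to compound 3 is a 1.3-fold lower number from compound 2 to compound 3 (0.10 log units; within the scatter), taken as within or barely beyond the scatter, in no firm direction. Compound 3 is therefore estimated at 5000 nM, with a range of 1500 nM to 20000 nM.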

Compound 3, half-maximal inhibitory concentration: 23300 nM
The estimate for compound 3 lay 4.7-fold (0.67 log units) below the measured number, outside the stated range (above it).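

In this assay the group on the carbonyl carbon proves able to move the read-out, as replacing 2-fluorophenyl with 4-chlorophenyl gives a 3.7-fold higher number from compound 2 to compound 3 (0.57 log units; beyond the scatter) and a weaker inhibitor. This single step changes the halogen and its ring position together, and the two contributions cannot be separated. No evidence on the cause of the step is available.

Going by these compounds, whether an unsubstituted phenyl or a methoxy or amine substituent on this ring would restore or exceed the activity of compound 2 stays open. Steps involving compound 1, the ethyl ester, cannot be read.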